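Swapping Isopropyl for Acetyl on an Aryl Urea

The source may report more compounds than this note shows. Statements on the series, on what has been measured and on what is new or still open speak of the compounds shown alone.

Three ureas have so far been measured in an ADME assay on the whole organism with Oryza sativa as the target, tested at 0.1 uM; on this read-out higher numbers stand for a weaker effect at the one concentration tested and lower numbers for a stronger effect. Compound 1 `CC(C)c1ccccc1NC(=O)N[C@H](C)c1ccccc1` gives 103%, and compound 2 `CC(C)c1ccccc1NC(=O)N[C@@H](C)c1ccccc1` gives 99%; the step of a number 4 percentage points lower from compound 1 to compound 2 (within the scatter) rests on (the fact that compounds 1 and 2 differ only in the configuration as drawn). Compound 3 `C[C@@H](NC(=O)Nc1cccc(C(F)(F)F)c1)c1ccccc1` gives 82%. Among these three numbers compound 2 stands second highest: its nearest neighbour is compound 1, and compound 3 lies furthest from it. Compound 3 differs from compound 2 in more than one place, so those two values can only be set side by side without a measured step between them.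

Compound 4 `CC(=O)c1ccccc1NC(=O)N[C@@H](C)c1ccccc1` is the next compound to be measured. It differs from compound 2 in one place: acetyl in place of isopropyl on an aromatic carbon. Within the data shown here, no measured step concerns this exchange of groups. Among the measured compounds shown here, the only measured step, from compound 1 to compound 2, concerns configuration alone and says nothing about the group on the ring. The values of compound 1 and compound 2 both sit near the top of the scale, which on this read-out means little effect at the one concentration tested. Compound 4 is therefore expected to show a step of a number 4 percentage points lower from compound 2 to compound 4 (within the scatter) in this assay, which is no step beyond the scatter. The estimate for compound 4 is 95%, with an expected range from 78% to 110%.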

Compound 4, a percentage reported as activity, at one concentration (the size of the read-out at that concentration, not a potency): 100%
For compound 4 the middle estimate is 5 percentage points below the measured one; the measured number falls inside the stated range.
By their numbers in this assay, from the lowest: compound 3; then compounds 2, 4 and 1 (each within the scatter of the next).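

Among these compounds, the first measured exchange of a group on the ring, acetyl in place of isopropyl on an aromatic carbon ortho to a large group, appears in this assay as a number 1 percentage points higher from compound 2 to compound 4 (within the scatter), so the two groups cannot be told apart on this read-out. This holds even though acetyl brings a double bond outside aromatic rings and a hydrogen-bond acceptor that isopropyl lacks, while the count of heavy atoms stays the same, so at this position, and in this one pair, those differences in the counted features come with no step beyond the scatter. Nothing measured here accounts for why the two groups read alike.

Still open, as far as these compounds go, is whether a group of another kind at this position, such as an amine, a carboxylic acid or a longer chain, would move the number beyond the scatter, or whether any group placed here can bring it down from the top of the scale. Also open, from the compounds shown here alone, is whether acetyl would read the same way with the opposite configuration at the chain carbon, and whether the likeness of isopropyl and acetyl would persist at any other concentration.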